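Carboxy analogue of compound 1 in the acid amidase series

A few compounds are considered here, and "the series" means these few. Any claim that something is new, unique, unknown or untested is made for them only; others in the source may bear on it.

Compound 1 `O=C(CCCCCCc1ccccc1)N1CCCC1` gives 12900 nM in an assay on HEK293 cells for inhibition of N-acylethanolamine-hydrolyzing acid amidase (Rattus norvegicus), read by LC-MS, with a stated time of 30 min (a lower number here means a stronger inhibitor, a higher number a weaker inhibitor), the highest of the two numbers shown, with compound 2 `O=C(CCCCCCc1cccc(F)c1)N1CCCC1` nearest at 7300 nM; the step of a 1.8-fold lower number from compound 1 to compound 2 (0.25 log units; within the scatter) stays within the scatter. Compound 3 `O=C(O)c1cccc(CCCCCCC(=O)N2CCCC2)c1` is recorded only as a limit of the assay, > 100000 nM (the limit of > 100000 nM in this assay, at which 1 of the 3 values shown sits). Compound 4 `O=C(O)c1ccc(CCCCCCC(=O)N2CCCC2)cc1` differs from compound 1 by carboxy in place of hydrogen on an aromatic carbon. The closest measured change, an at least 7.7-fold higher number from compound 1 to compound 3 (0.88 log units; beyond the scatter), introduces the same carboxy group on the aromatic ring, and an at least 13-fold higher number from compound 2 to compound 3 (1.13 log units; beyond the scatter) points the same way. A step of similar size and direction is therefore expected in this assay, a 12-fold higher number from compound 1 to compound 4 (1.07 log units; beyond the scatter). Compound 4 is estimated at 150000 nM, in the range 40000 nM to 600000 nM, and a limit rather than a number is considered likely.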

Compound 4, half-maximal inhibitory concentration: > 100000 nM
Compound 4 was reported as a limit; the forecaster's own chance of this, stated with the estimate: 70%; the middle value lies beyond the limit too.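

In this assay, carboxy para to a large group gives an at least 7.7-fold higher number from compound 1 to compound 4 (0.88 log units; beyond the scatter), so the weakening seen with compound 3 is not confined to a single ring position. Compound 3 and compound 4 both stand at a limit, so neither the order between them nor the full size of either step can be read: the limit of > 100000 nM in this assay, at which 2 of the 4 values shown sit.

As far as these compounds go, whether an amine or a methyl ester para to a large group would behave like the carboxy group remains open. So does whether fluoro at that position would match compound 2.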